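This account rests on a few compounds, and the source may have more. Where it says the series, first, only, none or still open, it means among the compounds named here.

Compound 1 `NC(=O)C[C@H](NC(=O)CN(c1nc(Cl)nc2[nH]cnc12)C1CC1)C(=O)O` carries a chloro-substituted core and a cyclopropyl group. In a functional assay on the whole organism (Tail, strain ICR) with Mus musculus as the target, in the tail flick test, with a stated time of 120 min, at a dose of 25 umol/kg by the oral route (on this read-out higher numbers stand for a stronger effect at the one dose given and lower numbers for a weaker effect), compound 1 gives 17%, the lower of the two values measured, while compound 2 `NC(=O)C[C@H](NC(=O)CN(c1ncnc2c1ncn2C1CCCCO1)C1CC1)C(=O)OCc1ccccc1` gives 29.2% in this assay, a number beyond the scatter above it. Compound 3 `O=C(O)C[C@H](NC(=O)CN(c1nc(Cl)nc2[nH]cnc12)C1CC1)C(=O)O` differs from compound 1 by hydroxy in place of amino on a carbonyl carbon. With no comparable single change measured, compound 3 is expected to stay close to compound 1, with an estimated step of a number 2 percentage points lower from compound 1 to compound 3 (within the scatter) that need not exceed the scatter. Compound 3 is therefore estimated at 15%, between 4% and 30%.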

Compound 3, a percentage reported as activity, at one dose (the size of the read-out at that dose, not a potency): 22%
Compound 3: middle estimate off by 7 percentage points, on the low side, and the stated range covers the measured number.
By their numbers in this assay, from the lowest: compounds 1, 3 and 2 (each within the scatter of the next, the first and the last beyond it).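

In this assay, the change from carbamoyl to carboxy on this side chain gives a number 5 percentage points higher from compound 1 to compound 3 (within the scatter). At this one dose, the amino and hydroxy forms of this carbonyl group therefore cannot be told apart, so this place accepts either group on the shared chloro-substituted core. No measurement given here accounts for this result. On these data alone, it remains open how a methyl ester or a methylamide would read at this carbonyl carbon. As far as these compounds go, whether carbamoyl and carboxy would still read alike at other doses or times also remains open.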